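Changing the Halogen Pattern on the Aniline of Compound 3

The compounds below may be only part of what the source reports. "The series", "measured", "known", "first", "only" and "open" are said of these compounds alone.

Three compounds share one core and differ only in the aryl group on the amine: compound 1 `COc1ccc(Nc2c(-c3ccc4[nH]nc(C)c4c3)nc3cnc(N4CCN(C)CC4)cn23)cc1`, compound 2 `Cc1ccc(C)c(Nc2c(-c3ccc4[nH]nc(C)c4c3)nc3cnc(N4CCN(C)CC4)cn23)c1` and compound 3 `Cc1n[nH]c2ccc(-c3nc4cnc(N5CCN(C)CC5)cn4c3Nc3ccc(Br)cc3Cl)cc12`. Among the compounds with values here, in a functional assay on MV4-11 cells (Homo sapiens) for inhibition, with a stated time of 120 h (a higher number here means a weaker inhibitor, a lower number a stronger inhibitor), compound 3 gives 9220 nM, the only number at hand. In this assay compound 1 gives "not determined" (no result reported) and compound 2 gives "not determined" (no result reported), so neither returned a result in this assay. Compound 3 therefore stands as a weak inhibitor with nothing measured to compare it against. Compound 4 `Cc1n[nH]c2ccc(-c3nc4cnc(N5CCN(C)CC5)cn4c3Nc3ccc(F)c(Cl)c3)cc12` carries the change (3-chloro-4-fluorophenyl in place of 4-bromo-2-chlorophenyl on a nitrogen on an aromatic ring). Within the data shown here, no measured pair shows what such a swap does here, so the step is expected to be small, in no firm direction, and probably within the scatter, as a 1.2-fold lower number from compound 3 to compound 4 (0.06 log units; within the scatter). Compound 4 is accordingly estimated at 8000 nM, within 2000 nM to 30000 nM.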

Compound 4, half-maximal inhibitory concentration: 2850 nM
Beside the measured number, compound 4's estimate is 2.8-fold (0.45 log units) above it; measured number inside the range.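

In this assay, the move to 3-chloro-4-fluorophenyl gives a 3.2-fold lower number from compound 3 to compound 4 (0.51 log units; beyond the scatter), the first sign that the aryl group on this nitrogen affects the read-out. The change swaps one halogen and alters the pattern of the other in a single step, so the share of each cannot be separated. No evidence at hand accounts for the difference. Going by these compounds, it remains open whether a single halogen alone would give a similar step, and how a nitrile or a carboxylic acid on this aryl ring would compare.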